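Working notes: the step from compound 2 to compound 3

The source may report more compounds than this note shows. Statements on the series, on what has been measured and on what is new or still open speak of the compounds shown alone.

Measured in a functional assay on EC9706 cells (Homo sapiens) for antiproliferative activity, read by MTT assay, with a stated time of 72 h; on this read-out higher numbers stand for weaker inhibition and lower numbers for stronger inhibition
- compound 1 `C/C(=N\NC(=O)c1cccc(S(=O)(=O)N2CCOCC2)c1)c1cccc(N)c1O` gives 3520 nM
- compound 2 `O=C(N/N=C/c1ccccc1O)c1cccc(S(=O)(=O)N2CCOCC2)c1` gives 19600 nM

Compound 2 (19600 nM) holds the higher of the two numbers, and its gap to compound 1 lies beyond the usual scatter. Among the measured compounds shown here, no two measured compounds differ in one place only, so no measured step guides the next change.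

Compound 3 `O=C(N/N=C/c1cc(Br)cc(Br)c1O)c1cccc(S(=O)(=O)N2CCOCC2)c1` departs from compound 2 in a single place (3,5-dibromo-2-hydroxyphenyl in place of 2-hydroxyphenyl on a carbon with a double bond to nitrogen). In this assay a moderate move toward a lower number, meaning stronger inhibition, is expected, although a result within the scatter of compound 2 would be no surprise. This direction is a judgement on the structural change alone. Compound 1 (3520 nM) shows only that a lower number occurs among these compounds. The expected change is modest (a 3.3-fold lower number from compound 2 to compound 3 (0.51 log units; beyond the scatter)). Compound 3 is expected at (6000 nM) with an estimated range (1500 nM to 20000 nM).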

Compound 3, half-maximal inhibitory concentration: 2440 nM
Estimate against measurement, compound 3: 2.5-fold (0.39 log units) above, within the range that was stated.
By their numbers in this assay, from the lowest: compounds 3 and 1 (each within the scatter of the next); then compound 2.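

In this assay the series now has its first step in one place, an 8.0-fold lower number from compound 2 to compound 3 (0.90 log units; beyond the scatter), with 3,5-dibromo-2-hydroxyphenyl in place of 2-hydroxyphenyl on a carbon with a double bond to nitrogen. It shows that the group at this place can move the read-out beyond the scatter, and that it does so with the counted hydrogen-bond donor, hydrogen-bond acceptor and net charge of the group unchanged, the difference in composition being the 2 bromine atoms. No measurement on these compounds gives a reason for the step.

Both bromine atoms enter together, so the step cannot tell whether one of them alone would give the same shift or whether the pair is needed. Also open, as far as these compounds go, are other groups in their place, such as chlorine, methoxy or an amine, and whether the 3,5-dibromo-2-hydroxyphenyl group would give a step of similar size on the core of compound 1.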